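A few compounds are considered here, and "the series" means these few. Any claim that something is new, unique, unknown or untested is made for them only; others in the source may bear on it.

Compound 3 `C=CC1=C(C(=O)NC(C)(C)C)C(c2ccc(F)cc2)OC1` stands at the floor of the numbers shown: in a functional assay on QGY7701 cells (Homo sapiens) for cytotoxicity, read by MTT assay, with a stated time of 24 h (a lower number here means a stronger inhibitor, a higher number a weaker inhibitor), compound 3 gives > 100000 nM, a limit of the assay rather than a number. Compound 4 `C=CC1=C(C(=O)Nc2ccccc2)C(c2ccc(F)cc2)OC1` differs from it by phenyl in place of tert-butyl on an amide-type nitrogen. Among the compounds with values here, two measured steps bear on this change. Compound 1 `C=CC1=C(C(=O)NCCC)C(c2ccc(F)cc2)OC1` likewise gives a limit, > 100000 nM. Compound 2 `C=CC1=C(C(=O)NCc2ccc(C)cc2)C(c2ccc(F)cc2)OC1` gives 62100 nM. Both steps that involve an aromatic ring on the amide side point the same way: an at least 1.6-fold lower number from compound 1 to compound 2 (0.20 log units; that floor lies within the scatter) and an at least 1.6-fold higher number from compound 2 to compound 3 (0.20 log units; that floor lies within the scatter), each only a floor because of the limit of > 100000 nM in this assay, at which 2 of the 3 values shown sit, while a step that the two limits leave unreadable from compound 1 to compound 3. A modest lowering of the number is therefore expected, of a size the floors cannot fix. Compound 4 is expected to give 70000 nM, between 30000 nM and 150000 nM, an expected step of an at least 1.4-fold lower number from compound 3 to compound 4 (0.15 log units; that floor lies within the scatter).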

Compound 4, half-maximal inhibitory concentration: 46700 nM
For compound 4 the middle estimate is 1.5-fold (0.18 log units) above the measured one; the measured number falls inside the stated range.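

With phenyl on the amide-type nitrogen, this assay now shows steps that clear the scatter: an at least 2.1-fold lower number from compound 3 to compound 4 (0.33 log units; beyond the scatter) and an at least 2.1-fold lower number from compound 1 to compound 4 (0.33 log units; beyond the scatter), whereas the steps involving compound 2 had given only floors within it. The 4-methylbenzyl and phenyl groups are not separated, with a 1.3-fold lower number from compound 2 to compound 4 (0.12 log units; within the scatter). Both larger steps remain floors, and their true size is unknown, because of this: the limit of > 100000 nM in this assay, at which 2 of the 4 values shown sit.

The compounds shown leave open whether a saturated ring such as cyclohexyl would serve in place of phenyl. They also leave open what a methoxy group or a chlorine on the phenyl would do.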